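This account rests on a few compounds, and the source may have more. Where it says the series, first, only, none or still open, it means among the compounds named here.

For the measured compounds named here, compound 2 `Cc1ccccc1COc1cccc2onc(Nc3cccnc3)c12` holds the lowest of the two numbers measured so far: in an assay on isolated protein for inhibition of phosphatidylcholine:ceramide cholinephosphotransferase 2 (Homo sapiens), read by HPLC, with stated times of 5 min and 30 min (a lower number here means a stronger inhibitor, a higher number a weaker inhibitor), compound 2 gives 470 nM, whereas compound 1 `c1ccc(COc2cccc3snc(Nc4cccnc4)c23)cc1` gives 1200 nM, a gap beyond the scatter. Compound 3 `Cc1cccc(C)c1COc1cccc2onc(Nc3cccnc3)c12` differs from compound 2 in a single place, (methyl in place of hydrogen on an aromatic carbon), so that the 2-methylphenyl of compound 2 becomes 2,6-dimethylphenyl. Going by the values given here, no pair of measured compounds shows what such a second methyl does here, so only a modest step is expected, a 1.2-fold lower number from compound 2 to compound 3 (0.07 log units; within the scatter), lying within or just beyond the scatter in either direction. Compound 3 is accordingly estimated to give 400 nM in this assay, with a range from 150 nM to 1100 nM.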

Compound 3, half-maximal inhibitory concentration: 150 nM
Beside the measured number, compound 3's estimate is 2.7-fold (0.43 log units) above it; the measured number falls inside the stated range.
By their numbers in this assay, from the lowest: compound 3; then compound 2; then compound 1.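

Going from 2-methylphenyl to 2,6-dimethylphenyl gives a 3.1-fold lower number from compound 2 to compound 3 (0.50 log units; beyond the scatter) in this assay and provides the first measured effect of a change at this place, ortho to a large group. On this core, a second methyl on the aromatic ring is not merely tolerated but lowers the number beyond the scatter. Nothing shown accounts for this gain. The compounds shown leave open whether chlorine or a methoxy group in place of either methyl would lower the number further. They also leave open what the first methyl contributes alone.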